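The source may report more compounds than this note shows. Statements on the series, on what has been measured and on what is new or still open speak of the compounds shown alone.

Compound 1 `Cc1cc(N[C@H](CCCCN)C(=O)NO)cc(C)c1F` stands only at a limit of the assay in a physicochemical assay for solubility, in phosphate buffer; a higher number here means a more soluble compound, a lower number a less soluble compound: in that assay compound 1 gives > 5 ug/mL, which is a limit and not a number. Compound 2 `Cc1ccc(CNCCCC[C@@H](Nc2cc(C)c(F)c(C)c2)C(=O)NO)cc1` likewise gives only a limit in this assay, > 5 ug/mL. Among the measured compounds shown here, the single step that bears on the series, a step that the two limits leave unreadable from compound 1 to compound 2, cannot be sized since (the limit of > 5 ug/mL in this assay, at which 2 of the 2 values shown sit). Compound 3 `Cc1cc(N[C@H](CCCCNCc2ccc([N+](=O)[O-])cc2)C(=O)NO)cc(C)c1F` differs from compound 1 by 4-nitrobenzyl in place of hydrogen on an amine nitrogen. The step in this assay is therefore expected to be a step that the limit leaves unreadable from compound 1 to compound 3, with no direction readable beyond the scatter. Compound 3 is estimated at 20 ug/mL, between 5 ug/mL and 80 ug/mL, most likely reported again only as a limit.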

Compound 3, solubility: > 5 ug/mL
Compound 3: only a limit was reported (the forecaster's own chance of this, stated with the estimate: 70%); the middle value lies beyond the limit too.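

No step among compound 1, compound 2 and compound 3 can be read in this assay, because all three give only a limit: the limit of > 5 ug/mL in this assay, at which 3 of the 3 values shown sit.

The compounds shown leave open how far each true value lies past that limit, and whether 4-methylbenzyl or 4-nitrobenzyl on the amine nitrogen shifts the read-out at all.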